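Cytotoxicity notes on the imine series, toward compound 4

The source may report more compounds than this note shows. Statements on the series, on what has been measured and on what is new or still open speak of the compounds shown alone.

Measured so far in a functional assay on HeLa cells (Homo sapiens) for cytotoxicity, read by MTT assay, with a stated time of 48 h, tested at 50 uM; on this read-out higher numbers stand for a stronger effect at the one concentration tested and lower numbers for a weaker effect:
compound 1 `CSc1ccc(/C=N/n2c(Cc3ccc(S(C)(=O)=O)cc3)n[nH]c2=S)cc1`: 57.5%
compound 2 `CS(=O)(=O)c1ccc(Cc2n[nH]c(=S)n2/N=C/c2cccnc2)cc1`: 14%
compound 3 `CS(=O)(=O)c1ccc(Cc2n[nH]c(=S)n2/N=C/c2c(F)cccc2Cl)cc1`: 70.6%

Compound 3 stands highest of the three numbers in this assay; compound 1 sits nearest to it and compound 2 furthest. All three share one core and differ only in the group on the carbon with a double bond to nitrogen. On that carbon, a number 13.1 percentage points higher from compound 1 to compound 3 (beyond the scatter), whereas a number 43.5 percentage points lower from compound 1 to compound 2 (beyond the scatter) and a number 56.6 percentage points higher from compound 2 to compound 3 (beyond the scatter). The one ring with a hetero atom in the set is thus tied to the weakest number, while both carbon-only rings give strong ones.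

Compound 4 `CS(=O)(=O)c1ccc(Cc2n[nH]c(=S)n2/N=C/c2cccs2)cc1` has not been measured. It differs from compound 3 in one place: thiophen-2-yl in place of 2-chloro-6-fluorophenyl on a carbon with a double bond to nitrogen. Within the data shown here, the steps that bear on this are those between compound 2 and its two carbon-only neighbours, both large, both pointing the same way: a ring with a hetero atom on this carbon lowered the read-out. Whether a five-membered ring with sulfur behaves like pyridin-3-yl is not known from these three compounds, so the expected fall is taken as real but uncertain in size. Compound 4 is expected to give 35%, within 12% to 58%, which means an expected step of a number 35.6 percentage points lower from compound 3 to compound 4 (beyond the scatter).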

Compound 4, a percentage reported as activity, at one concentration (the size of the read-out at that concentration, not a potency): 48.6%
Compound 4: middle estimate off by 13.6 percentage points, on the low side; the range from low to high includes it.
By their numbers in this assay, from the lowest: compound 2; then compounds 4 and 1 (each within the scatter of the next); then compound 3.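

In this assay, a ring with a hetero atom on the carbon with a double bond to nitrogen does not by itself go with a low read-out: the step (a number 34.6 percentage points higher from compound 2 to compound 4 (beyond the scatter)) separates thiophen-2-yl widely from pyridin-3-yl. The carbon-only rings do not behave as one group against thiophen-2-yl either, since one step is beyond the scatter (a number 22 percentage points lower from compound 3 to compound 4 (beyond the scatter)) and the other is not (a number 8.9 percentage points lower from compound 1 to compound 4 (within the scatter)). Compound 2 is now the lone low point among the four, and the earlier link between a hetero atom and a weak number holds for pyridin-3-yl only, with compound 4 going against it. Nothing at hand accounts for these differences between the rings.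

Open, from the compounds shown here alone, is whether the step from compound 3 to compound 4 follows the change of ring or the loss of chlorine and fluorine, which plain phenyl on the same carbon would help to separate. Also open, going by these compounds, is whether the low number of compound 2 recurs with furan-2-yl, or with a phenyl ring carrying a dimethylamino group or a carboxylic acid.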